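Isopentyl in place of isopropyl on the ring nitrogen

The source may hold more compounds than are shown below. What is called first, only, known or untested is meant among the compounds shown, and "the series" means these compounds.

In an ADME assay on a cell-free system (plasma, Rattus norvegicus), with a stated time of 60 min (on this read-out higher numbers stand for a more stable compound and lower numbers for a less stable compound), compound 3 (`CC(C)N1Cc2cc(OCc3cccc(-c4ccc(Cl)c(C(=O)O)c4)c3)ccc2C1=O`) gives 98%. Compound 1 (`O=C(O)c1cc(-c2cccc(COc3ccc4c(=O)n(C5CCCC5)oc4c3)c2)ccc1Cl`) gives 100% and compound 2 (`O=C(O)c1cc(-c2cccc(COc3ccc4c(c3)CN(CC3CC3)C4=O)c2)ccc1Cl`) gives 100%. Compound 3 therefore lies within the scatter of both of the others, and the three values cannot be ranked.

The next compound is compound 4 (`CC(C)CCN1Cc2cc(OCc3cccc(-c4ccc(Cl)c(C(=O)O)c4)c3)ccc2C1=O`), which differs from compound 3 in one place: isopentyl in place of isopropyl on an amide-type nitrogen in a ring. In words, isopentyl stands in place of isopropyl on an amide-type nitrogen in a ring.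

Going by the values given here, only one measured step bears on this change. It sits on the same nitrogen and replaces cyclopropylmethyl with isopropyl: a number 2 percentage points lower from compound 2 to compound 3 (within the scatter). Among the compounds with values here, that single step is small, but it does not test isopentyl, which no measured compound carries. The values of compound 1 and compound 2 show no loss in this assay either, although compound 1 has a different core.

On the evidence of compound 2 and compound 3, no change beyond the scatter is expected. The expected step is a number 2 percentage points lower from compound 3 to compound 4 (within the scatter). For compound 4 the estimated value is 96%, with an expected range from 86% to 100%.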

Compound 4, percent of the compound remaining: 94%
Estimate against measurement, compound 4: 2 percentage points above; measured number inside the range.
By their numbers in this assay, from the lowest: compounds 4, 3, 1 and 2 (each within the scatter of the next).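

In this assay, the isopentyl chain on the amide-type nitrogen in a ring, with 5 heavy atoms in place of the 3 of isopropyl, gives a number 4 percentage points lower from compound 3 to compound 4 (within the scatter), so this position accepts a longer branched chain without a step beyond the scatter. Read against the compound with cyclopropylmethyl on the same nitrogen, isobutyl in place of cyclopropyl on the saturated chain carbon gives a number 6 percentage points lower from compound 2 to compound 4 (within the scatter), so a chain with no ring also holds the reading inside the scatter, and the small ring in that substituent is not required for it. Nothing at hand gives a cause for either step.

On these data alone, whether a still longer chain, or a chain ending in an amine or a second carboxylic acid, would keep the reading on this nitrogen inside the scatter remains open. All the steps on this nitrogen lie within the scatter, so the compounds shown do not yet reveal which group here, if any, would bring a real loss in this assay.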